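Adding a Second Chlorine to Compound 3

A few compounds are considered here, and "the series" means these few. Any claim that something is new, unique, unknown or untested is made for them only; others in the source may bear on it.

Three compounds share one core and differ only in the ring that sits on a saturated chain carbon bound to an oxygen on an aromatic ring. In a functional assay on MGC-803 cells (Homo sapiens) for inhibition, read by MTT assay, with a stated time of 48 h (a lower number here means a stronger inhibitor, a higher number a weaker inhibitor), compound 1 `Cc1ccc(NC(=O)NC(=O)c2ccc(OCc3cccc(Cl)c3)cc2)cc1-c1nc2ccccc2[nH]1` gives 20800 nM, compound 2 `Cc1ccc(NC(=O)NC(=O)c2ccc(OCc3cccc(F)c3)cc2)cc1-c1nc2ccccc2[nH]1` gives 44800 nM and compound 3 `Cc1ccc(NC(=O)NC(=O)c2ccc(OCc3ccccc3Cl)cc2)cc1-c1nc2ccccc2[nH]1` gives 19500 nM. Among the compounds with values here, of the three numbers that of compound 3 is the lowest, though its gap to compound 1 stays within the scatter, as the step of a 1.1-fold lower number from compound 1 to compound 3 (0.03 log units; within the scatter) shows; only the step of a 2.3-fold lower number from compound 2 to compound 3 (0.36 log units; beyond the scatter) goes beyond it.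

Compound 4 `Cc1ccc(NC(=O)NC(=O)c2ccc(OCc3ccc(Cl)c(Cl)c3)cc2)cc1-c1nc2ccccc2[nH]1` carries 3,4-dichlorophenyl in place of 2-chlorophenyl on a saturated chain carbon bound to an oxygen on an aromatic ring. Within the data shown here, two measured steps bear on this. The step of a 1.1-fold lower number from compound 1 to compound 3 (0.03 log units; within the scatter) shows that exchanging 3-chlorophenyl for 2-chlorophenyl changes little, and the step of a 2.2-fold higher number from compound 1 to compound 2 (0.33 log units; beyond the scatter) shows that chlorine gives a lower number than fluorine. Among the measured compounds shown here, no measured pair adds a second chlorine, so for compound 4 a step of a 1.4-fold lower number from compound 3 to compound 4 (0.14 log units; within the scatter) in this assay is expected, at most a modest one toward a lower number. Compound 4 is therefore estimated at 14000 nM in this assay, within a range of 6000 nM to 33000 nM.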

Compound 4, half-maximal inhibitory concentration: 6080 nM
For compound 4 the middle estimate is 2.3-fold (0.36 log units) above the measured one; low and high end bracket the measured number.
By their numbers in this assay, from the lowest: compound 4; then compounds 3 and 1 (each within the scatter of the next); then compound 2.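

In this assay, the step with chloro in place of hydrogen on an aromatic carbon, a 3.4-fold lower number from compound 1 to compound 4 (0.53 log units; beyond the scatter), shows that a second chlorine on this ring lowers the number beyond the scatter, whereas exchanging 3-chlorophenyl for 2-chlorophenyl had changed little. The exchange of 2-chlorophenyl for 3,4-dichlorophenyl gives a 3.2-fold lower number from compound 3 to compound 4 (0.51 log units; beyond the scatter), and the exchange of 3-fluorophenyl for 3,4-dichlorophenyl gives a 7.4-fold lower number from compound 2 to compound 4 (0.87 log units; beyond the scatter), so compound 4 has the lowest number of the four and this position has a wider range than the three earlier compounds suggested. Nothing measured here explains why the number falls.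

From the compounds shown here alone, all four compounds carry only chlorine or fluorine on this ring, so it remains open whether a second fluorine would give a similar step. Going by these compounds, it also remains open how a methoxy group or an amine on this ring would compare.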